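The compounds below may be only part of what the source reports. "The series", "measured", "known", "first", "only" and "open" are said of these compounds alone.

In an ADME assay on HEK-293T cells (Homo sapiens) for cytotoxicity, read by MTT assay, with a stated time of 48 h (on this read-out higher numbers stand for lower toxicity in this test and lower numbers for higher toxicity in this test), three compounds built on the same bicyclic ester or amide core have been measured. Compound 1 `CC1CCN(CC(=O)O[C@@H]2C[C@@H]3CC[C@@]2(C)C3(C)C)CC1` gives 71600 nM. Compound 2 `CN1CCN(CC(=O)O[C@@H]2C[C@@H]3CC[C@@]2(C)C3(C)C)CC1` gives 313000 nM. Compound 3 `CN1CCN(CC(=O)N[C@@H]2C[C@H]3CC[C@]2(C)C3(C)C)CC1` gives 853000 nM, the highest of the three numbers, and the difference between its core and that of compound 2 is not broken down here; their two values simply show compound 3 standing higher than compound 2.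

Between compound 2 and compound 1 a single change is made, (4-methylpiperidin-1-yl in place of 4-methylpiperazin-1-yl on a saturated chain carbon bound to a carbonyl carbon), and it produces a 4.4-fold lower number from compound 2 to compound 1 (0.64 log units; beyond the scatter).

Compound 4 `CC1CCN(CC(=O)N[C@@H]2C[C@H]3CC[C@]2(C)C3(C)C)CC1` has not yet been measured. Going by the values given here, it differs from compound 3 by 4-methylpiperidin-1-yl in place of 4-methylpiperazin-1-yl on a saturated chain carbon bound to a carbonyl carbon, which is the same change as the one made from compound 2 to compound 1, at the same place. Among the compounds with values here, because the only observed instance of this change gave a 4.4-fold lower number from compound 2 to compound 1 (0.64 log units; beyond the scatter), a step of similar size downward is expected from compound 3 to compound 4, estimated as a 4.3-fold lower number from compound 3 to compound 4 (0.63 log units; beyond the scatter), with the caution that this rests on one pair alone. On that basis compound 4 is expected to give about 200000 nM in this assay, plausibly lying between 70000 nM and 600000 nM.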

Compound 4, half-maximal cytotoxic concentration: 78000 nM
For compound 4 the middle estimate is 2.6-fold (0.41 log units) above the measured one; the measured number falls inside the stated range.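

In this assay, placing 4-methylpiperidin-1-yl in place of 4-methylpiperazin-1-yl on a saturated chain carbon bound to a carbonyl carbon again goes downward, giving an 11-fold lower number from compound 3 to compound 4 (1.04 log units; beyond the scatter). Set beside the earlier step, the two point the same way and cannot be told apart in size: the same change on two cores in this assay, a 4.4-fold lower number (0.64 log units; beyond the scatter) from compound 2 to compound 1 and an 11-fold lower number (1.04 log units; beyond the scatter) from compound 3 to compound 4, 2.5-fold (0.40 log units) apart, within the scatter of two such steps. The change therefore carries over between the core of compound 2 and the core of compound 3, but this rests on two pairs alone; it shows nothing about other cores and does not explain why the number falls.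

The compounds shown leave open what other groups would do at this place, such as a morpholine ring, an unsubstituted piperidine or an open-chain dimethylamine. They also leave open whether the step would keep its direction and size on a core other than these two, or in a cell line other than this one.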